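Bromo to methoxy on the sulfonyl aryl group

This account rests on a few compounds, and the source may have more. Where it says the series, first, only, none or still open, it means among the compounds named here.

In a functional assay on DU-145 cells (Homo sapiens) for inhibition, read by trypan blue exclusion, with a stated time of 96 h (on this read-out higher numbers stand for weaker inhibition of growth and lower numbers for stronger inhibition of growth), compound 3 (`O=C(/C(=C\c1ccccc1OCc1ccccc1)S(=O)(=O)c1ccc(Br)cc1)c1ccc(Cl)cc1`) gives 1000 nM and stands level with compound 1 (`O=C(/C(=C\c1ccccc1OCc1ccccc1)SCc1ccc(F)cc1)c1ccc(Cl)cc1`) at 1000 nM as the lowest of the three numbers, while compound 2 (`O=C(/C(=C\c1ccccc1OCc1ccccc1)SCc1ccc(Cl)c(Cl)c1)c1ccc(Cl)cc1`) gives 10000 nM in the same test. Compound 4 (`COc1ccc(S(=O)(=O)/C(=C/c2ccccc2OCc2ccccc2)C(=O)c2ccc(Cl)cc2)cc1`) differs from compound 3 as follows: methoxy in place of bromo on an aromatic carbon (methoxy in place of bromo, para to a large group). Among the compounds with values here, no measured step makes this exact change. Exchanging the whole sulfur arm gave no change at the digits printed from compound 1 to compound 3 (within the scatter) and so no shift, yet the benzyl ring change gave a 10-fold higher number from compound 1 to compound 2 (1.00 log units; beyond the scatter) as a warning, and a 10-fold lower number from compound 2 to compound 3 (1.00 log units; beyond the scatter) mirrors it. The expected size in this assay is a 1.5-fold higher number from compound 3 to compound 4 (0.18 log units; within the scatter) and thus nothing beyond the scatter, with no firm direction. Estimated for compound 4: 1500 nM within 400 nM to 7000 nM as the expected range.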

Compound 4, concentration for 50% growth inhibition: 1000 nM
For compound 4 the middle estimate is 1.5-fold (0.18 log units) above the measured one; the measured number falls inside the stated range.
By their numbers in this assay, from the lowest: compounds 1, 3 and 4 (each within the scatter of the next); then compound 2.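

In this assay, within the data shown here, the one step made on the sulfonyl aryl ring itself reads no change at the digits printed from compound 3 to compound 4 (within the scatter), so on this aromatic carbon, para to a large group, methoxy and bromo cannot be told apart. The methoxy sulfonyl compound also gives no change at the digits printed from compound 1 to compound 4 (within the scatter) and a 10-fold lower number from compound 2 to compound 4 (1.00 log units; beyond the scatter), repeating the picture of compound 3 with a second sulfonyl member. No evidence on hand bears on this result.

Going by these compounds, whether an amine or a carboxylic acid on that carbon would move the number stays open. So does the reading of a 3,4-dichlorophenyl group on the sulfonyl.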